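A few compounds are considered here, and "the series" means these few. Any claim that something is new, unique, unknown or untested is made for them only; others in the source may bear on it.

Measured compounds:
Compound 1 `CCOc1cc(NC(=O)NCc2cc(C)c(N3CC(C)OC(C)C3)cn2)cc(Cl)n1` gives 105 nM in a functional assay on HFL1 cells for antagonist activity at sphingosine 1-phosphate receptor 2 (Homo sapiens), read by ELISA, with a stated time of 24 h, in the absence of a further agent; on this read-out higher numbers stand for weaker inhibition and lower numbers for stronger inhibition.
Compound 2 `Cc1cc(CNC(=O)Nc2cc(Cl)nc(OCC(F)F)c2)nnc1-c1cn(C)nc1C(F)(F)F` gives 36 nM in this assay.

Of the two numbers, compound 2 gives the lower one, and its gap to compound 1 lies beyond the usual scatter, so compound 2 stands as the stronger inhibitor here. The two differ in several places at once, so no single change can be read out of that gap.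

Compound 3 `COCCOc1cc(NC(=O)NCc2cc(C)c(-c3cn(C)nc3C(F)(F)F)nn2)cc(Cl)n1` is the next step. It keeps the whole frame of compound 2 and changes only the chain hanging from the aromatic oxygen: methoxymethyl in place of difluoromethyl on a saturated chain carbon bound to an oxygen on an aromatic ring. Both groups are small and uncharged; the incoming one brings one hydrogen-bond acceptor where the outgoing one had none. For the measured compounds named here, with no measured pair showing this change, the expected step is small, a 1.3-fold higher number from compound 2 to compound 3 (0.10 log units; within the scatter), not beyond the scatter and with no firm direction. Compound 3 is therefore expected near 45 nM, within 15 nM to 140 nM.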

Compound 3, half-maximal inhibitory concentration: 640 nM
For compound 3 the middle estimate is 14-fold (1.15 log units) below the measured one; measured number outside the range, above it.
By their numbers in this assay, from the lowest: compound 2; then compound 1; then compound 3.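

In this assay, this position is far from indifferent: putting methoxymethyl in place of difluoromethyl, on a saturated chain carbon bound to an oxygen on an aromatic ring, gives an 18-fold higher number from compound 2 to compound 3 (1.25 log units; beyond the scatter), a clear loss of inhibition with the rest of the molecule unchanged. Compound 1 and compound 2 differ in several places, so they could not reveal this; the new pair isolates this one place and shows that swapping two groups with the same heavy-atom count can have a large effect. Nothing available here bears on the reason for this loss.

From the compounds shown here alone, it remains open how a 2,2,2-trifluoroethoxy or 2-hydroxyethoxy group would behave at this place on the same core. Whether the step would keep its size on the core of compound 1 is also unknown.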